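Swapping methoxy for fluoro on a shared thiazole-hydrazide core

A few compounds are considered here, and "the series" means these few. Any claim that something is new, unique, unknown or untested is made for them only; others in the source may bear on it.

Of the compounds shown here, three with a shared core have been measured in a functional assay on C6 cells (Rattus norvegicus) for cytotoxicity, read by MTT assay, with a stated time of 24 h, tested at 50 ug/mL; on this read-out higher numbers stand for a weaker effect at the one concentration tested and lower numbers for a stronger effect. Compound 1 `Cc1nnc(SCC(=O)N/N=c2/scc(-c3ccc(F)cc3)n2-c2ccccc2)s1` gives 37.4%. Compound 2 `O=C(CSc1ncccn1)N/N=c1/scc(-c2ccc(Cl)cc2)n1-c1ccccc1` gives 61.8%, and compound 3 `COc1ccc(-c2cs/c(=N/NC(=O)CSc3ncccn3)n2-c2ccccc2)cc1` gives 66.5%. Compound 3 therefore stands highest of the three numbers, with compound 2 nearest, and the gap between compound 3 and compound 1 is the only one that reaches beyond the usual scatter.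

The step to the unmeasured compound 4 `O=C(CSc1ncccn1)N/N=c1/scc(-c2ccc(F)cc2)n1-c1ccccc1` is a single change on the six-membered carbon ring, at the position para to a large group: fluoro in place of methoxy on an aromatic carbon.

Going by the values given here, only one measured step touches that same position: a number 4.7 percentage points higher from compound 2 to compound 3 (within the scatter), a change that stayed within the scatter. Compound 1 also carries fluoro on that ring, but it differs from compound 3 elsewhere as well, so its lower number cannot be assigned to the fluoro alone; it only shows that fluoro compounds on a related core can read lower.

Given that the chloro-to-methoxy swap on this core barely moved this assay, the step from compound 3 to compound 4 is expected to be small, a number 8.5 percentage points lower from compound 3 to compound 4 (within the scatter), with a slight downward lean. Compound 4 is therefore estimated at 58%, within a range of 40% to 74%.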

Compound 4, a percentage reported as activity, at one concentration (the size of the read-out at that concentration, not a potency): 55.5%
Estimate against measurement, compound 4: 2.5 percentage points above; measured number inside the range.
By their numbers in this assay, from the lowest: compound 1; then compounds 4, 2 and 3 (each within the scatter of the next, the first and the last beyond it).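

In this assay this position proves able to move the number: fluoro in place of methoxy gives a number 11 percentage points lower from compound 3 to compound 4 (beyond the scatter) and so a modestly stronger effect at the one concentration tested. Chloro cannot be separated from either of the other two groups, since fluoro in its place gives a number 6.3 percentage points lower from compound 2 to compound 4 (within the scatter) and only methoxy and fluoro can be told apart here. Compound 4 also forms a clean pair with compound 1, as both carry fluoro and differ only in the group on the sulfur, and that exchange gives a number 18.1 percentage points higher from compound 1 to compound 4 (beyond the scatter) so the low number of compound 1 goes with its 5-methyl-1,3,4-thiadiazol-2-yl group and not with fluoro.

Going by these compounds, it remains open whether an amine or a carboxylic acid at this position would shift the number further, or whether a plain hydrogen there would read like fluoro. On these data alone, it is also open whether the gain seen with 5-methyl-1,3,4-thiadiazol-2-yl on the sulfur would hold with methoxy or chloro on the six-membered ring.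

No other measurement here offers an explanation for these differences.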